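The source may hold more compounds than are shown below. What is called first, only, known or untested is meant among the compounds shown, and "the series" means these compounds.

Working notes on the series. In a functional assay on HepG2 cells (Homo sapiens) for cytotoxicity, read by MTT assay, with a stated time of 24 h (on this read-out higher numbers stand for weaker inhibition and lower numbers for stronger inhibition), compound 1 (`N#Cc1ccc(/C=C2\CN(S(=O)(=O)c3ccc(F)cc3)C/C(=C\c3ccc(C#N)cc3)C2=O)cc1`) gives 11500 nM. In this assay compound 2 (`COc1cc(/C=C2\CN(S(=O)(=O)c3ccc(F)cc3)C/C(=C\c3ccccc3F)C2=O)cc(OC)c1OC`) gives 7940 nM, which places compound 2 within the scatter of compound 1, so the two numbers cannot be ranked. Among the compounds with values here, no measured pair differing in one place exists yet, so the size of a single change is unknown. Compound 3 (`COc1cc(/C=C2\CN(S(=O)(=O)c3ccc(F)cc3)C/C(=C\c3ccc(C#N)cc3)C2=O)cc(OC)c1OC`) comes from compound 2 by 4-cyanophenyl in place of 2-fluorophenyl on a double-bonded chain carbon bound to a double-bonded ring carbon. The 4-cyanophenyl group also occurs in compound 1, at 11500 nM. No step beyond the scatter is expected in this assay, and no direction can be given. The estimated 1.1-fold higher number from compound 2 to compound 3 (0.05 log units; within the scatter) lies within the scatter. For compound 3 the estimated value is 9000 nM, with an expected range of 4500 nM to 18000 nM.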

Compound 3, half-maximal inhibitory concentration: 4950 nM
Compound 3: the middle estimate sits 1.8-fold (0.26 log units) above what was measured; measured number inside the range.
By their numbers in this assay, from the lowest: compounds 3, 2 and 1 (each within the scatter of the next, the first and the last beyond it).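

In this assay, 4-cyanophenyl in place of 2-fluorophenyl on a double-bonded chain carbon bound to a double-bonded ring carbon gives a 1.6-fold lower number from compound 2 to compound 3 (0.21 log units; within the scatter), so this exchange cannot be ranked. Within the data shown here, at the same kind of place, 3,4,5-trimethoxyphenyl in place of 4-cyanophenyl gives a 2.3-fold lower number from compound 1 to compound 3 (0.37 log units; beyond the scatter), the first single change to pass the scatter, though only modestly. No measurement available here accounts for either step.

Whether 3,4,5-trimethoxyphenyl in place of 2-fluorophenyl gives a step of similar size remains open, since the compounds shown hold no such pair. Also open, going by these compounds, is how a phenyl group carrying an amine or a carboxylic acid would read at this place.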